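This account rests on a few compounds, and the source may have more. Where it says the series, first, only, none or still open, it means among the compounds named here.

Working notes on the series. Among the compounds with values here, compound 2 `CC(C)C[C@H](N)c1cc(C(F)(F)F)ccc1N1CCN(C(=O)CCC2CCCCC2)CC1` gives 5700 nM in an assay on HEK293 cells for displacement of a labelled ligand from Melanocortin receptor 4 (Homo sapiens) (on this read-out lower numbers stand for stronger inhibition and higher numbers for weaker inhibition), and stands at the highest of the two numbers known so far; its nearest neighbour is compound 1 `Cc1ccc(OCC(=O)N2CCN(c3ccc(C(F)(F)F)cc3[C@@H](N)CC(C)C)CC2)cc1`, which gives 4400 nM in this assay. Within the data shown here, the only measured step, a 1.3-fold higher number from compound 1 to compound 2 (0.11 log units; within the scatter), exchanges a 4-methylphenoxy group for a cyclohexylmethyl group and leaves the number essentially where it was.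

Compound 3 `Cc1cc(CC(C)C(=O)N2CCN(c3ccc(C(F)(F)F)cc3[C@@H](N)CC(C)C)CC2)ccc1Cl` is the next untested member. It differs from compound 2 as follows: 1-(4-chloro-3-methylbenzyl)ethyl in place of 2-cyclohexylethyl on a carbonyl carbon. The change returns an aromatic six-membered ring to the chain on the carbonyl carbon, now carrying chlorine and a methyl group and with a branch next to the carbonyl. Among the measured compounds shown here, the single measured step bearing on this position, a 1.3-fold higher number from compound 1 to compound 2 (0.11 log units; within the scatter), was within the scatter, so no clear direction is indicated. The expected shift a 1.4-fold lower number from compound 2 to compound 3 (0.15 log units; within the scatter) is therefore small, and compound 3 is estimated to give 4000 nM in this assay, within a range of 1300 nM to 12000 nM.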

Compound 3, inhibition constant: 71 nM
The estimate for compound 3 lay 56-fold (1.75 log units) above the measured number; the whole stated range lies above it.
By their numbers in this assay, from the lowest: compound 3; then compounds 1 and 2 (each within the scatter of the next).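

The group on the carbonyl carbon turns out to be far from indifferent, as the first two compounds had suggested: in this assay, 1-(4-chloro-3-methylbenzyl)ethyl in place of 2-cyclohexylethyl gives an 80-fold lower number from compound 2 to compound 3 (1.90 log units; beyond the scatter), and in place of (4-methylphenoxy)methyl it gives a 62-fold lower number from compound 1 to compound 3 (1.79 log units; beyond the scatter). Compound 1 also carries a six-membered aromatic ring in its (4-methylphenoxy)methyl group yet stands within the scatter of compound 2, so such a ring alone does not set the number. Nothing at hand gives a cause for this large step.

The chlorine, the methyl group and the branched chain all enter together in compound 3, and the compounds shown do not separate their contributions. Going by these compounds, whether a fluorine in place of the chlorine, a hydrogen in place of the ring methyl group, or an unbranched chain would keep the number remains open.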